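The source may report more compounds than this note shows. Statements on the series, on what has been measured and on what is new or still open speak of the compounds shown alone.

In a functional assay on HT cells (Homo sapiens) for antiproliferative activity, read by fluorescence, with a stated time of 72 h (a lower number here means a stronger inhibitor of growth, a higher number a weaker inhibitor of growth), compound 3 `CC(C)c1n[nH]c2c(NCc3ccc(-c4ccccn4)cc3)nc(SCCN)nc12` gives 22 nM, the lowest of the three numbers, against compound 1 `CC(C)c1n[nH]c2c(NCc3ccc(-c4ccccn4)cc3)nc(SCC3CNC(=O)O3)nc12` at 80 nM and compound 2 `CSc1nc(NCc2ccc(-c3ccccn3)cc2)c2[nH]nc(C(C)C)c2n1` at 783 nM. Compound 4 `CC(C)c1n[nH]c2c(NCc3ccc(-c4ccccn4)cc3)nc(SCCCO)nc12` departs from compound 3 by hydroxymethyl in place of amino on a saturated chain carbon, two bonds along the chain from a sulfur. Among the measured compounds shown here, two measured steps bear on this change, both ending at the amino-bearing chain. The first, a 36-fold lower number from compound 2 to compound 3 (1.55 log units; beyond the scatter), is large, while the second, a 3.6-fold lower number from compound 1 to compound 3 (0.56 log units; beyond the scatter), is modest. Neither tests a hydroxyl-ended chain directly, so a modest step to a higher number is expected in this assay. The estimate means an expected 4.1-fold higher number from compound 3 to compound 4 (0.61 log units; beyond the scatter). Compound 4 is estimated at 90 nM, with an expected range of 30 nM to 270 nM.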

Compound 4, concentration for 50% growth inhibition: 109 nM
Compound 4: middle estimate off by 1.2-fold (0.08 log units), on the low side; low and high end bracket the measured number.
By their numbers in this assay, from the lowest: compound 3; then compounds 1 and 4 (each within the scatter of the next); then compound 2.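

In this assay, the 3-hydroxypropyl chain keeps part of the gain over the bare chain of compound 2 (a 7.2-fold lower number from compound 2 to compound 4 (0.86 log units; beyond the scatter)), so that gain does not depend on an amine end. It falls short of the 2-aminoethyl chain (a 5.0-fold higher number from compound 3 to compound 4 (0.70 log units; beyond the scatter)) and cannot be separated from the ring-bearing chain of compound 1 (a 1.4-fold higher number from compound 1 to compound 4 (0.13 log units; within the scatter)). No measurement here accounts for these differences. End group and chain length change together between compound 3 and compound 4, leaving their contributions unresolved. On these data alone, a 3-aminopropyl or 2-hydroxyethyl chain would separate them, and a carboxylic acid end remains untested.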